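Swapping fluorine for chlorine on a triazole-linked aryl ring

The source may hold more compounds than are shown below. What is called first, only, known or untested is meant among the compounds shown, and "the series" means these compounds.

Compound 1 `C=C1C[C@]23C[C@@]1(O)CC[C@@H]2c1cccc(C)c1[C@@H]3Cn1cc(-c2ccc(OC)cc2)nn1` and compound 2 `C=C1C[C@]23C[C@@]1(O)CC[C@H]2c1ccc(O)c(C)c1[C@@H]3Cn1cc(-c2ccc(F)cc2)nn1` share a core with compound 3 `C=C1C(=O)[C@]23C[C@@]1(O)CC[C@H]2c1ccc(OS(=O)(=O)c2ccc(C)cc2)c(C)c1[C@@H]3Cn1cc(-c2ccc(F)cc2)nn1`. In a functional assay on SMMC-7721 cells (Homo sapiens) for cytotoxicity, read by MTT assay, with a stated time of 4 days (a lower number here means a stronger inhibitor, a higher number a weaker inhibitor), compound 1 gives only a limit, > 20000 nM. Compound 2 likewise gives only a limit, > 20000 nM. For the measured compounds named here, compound 3 stands alone as the one measured number, 4280 nM, while the limit of > 20000 nM in this assay, at which 2 of the 3 values shown sit, marks where the other two sit. Compound 4 `C=C1C(=O)[C@]23C[C@@]1(O)CC[C@H]2c1ccc(OS(=O)(=O)c2ccc(C)cc2)c(C)c1[C@@H]3Cn1cc(-c2ccc(Cl)cc2)nn1` differs from compound 3 in one place: chloro in place of fluoro on an aromatic carbon. Going by the values given here, no step between two measured compounds exists for this kind of change, so the expectation is a step that stays within the usual scatter, leaning slightly toward stronger inhibition. Compound 4 is expected to give 3000 nM, between 1200 nM and 9000 nM, which corresponds to an expected step of a 1.4-fold lower number from compound 3 to compound 4 (0.15 log units; within the scatter).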

Compound 4, half-maximal inhibitory concentration: 6180 nM
Compound 4: middle estimate off by 2.1-fold (0.31 log units), on the low side, within the range that was stated.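

In this assay, for the compounds shown here, the first measured step in this set shows that replacing fluoro with chloro, on an aromatic carbon para to a large group, gives a 1.4-fold higher number from compound 3 to compound 4 (0.16 log units; within the scatter). This position therefore tolerates the exchange of one halogen for the other without a change that can be told from the scatter. Nothing shown explains this result.

Going by these compounds, what an amine, a carboxylic acid or a longer chain would do at this position stays open. So does whether this swap would behave the same way on the core of compound 2.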